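A few compounds are considered here, and "the series" means these few. Any claim that something is new, unique, unknown or untested is made for them only; others in the source may bear on it.

Measured so far in a functional assay on MGC-803 cells (Homo sapiens) for inhibition, read by MTT assay, with a stated time of 72 h (on this read-out higher numbers stand for weaker inhibition and lower numbers for stronger inhibition), for the series
compound 1 `Cc1cc(N2CC[C@@H](C)[C@@H](N(C)c3ncnc4[nH]ccc34)C2)n2nc(SCc3ccccc3Br)nc2n1` gives 27000 nM in this assay
compound 2 `Cc1nc2nc(SCc3ccc(Cl)cc3)nn2c(N2CC[C@@H](C)[C@@H](N(C)c3ncnc4[nH]ccc34)C2)c1C` gives 90500 nM in this assay
compound 3 `Cc1cc(N2CC[C@@H](C)[C@@H](N(C)c3ncnc4[nH]ccc34)C2)n2nc(SCc3ccc(F)cc3)nc2n1` gives 11900 nM in this assay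

Compound 3 holds the lowest of the three numbers, with both gaps to the others beyond the scatter. Compound 4 `Cc1cc(N2CC[C@@H](C)[C@@H](N(C)c3ncnc4[nH]ccc34)C2)n2nc(SCc3cc(Cl)ccc3Cl)nc2n1` carries 2,5-dichlorophenyl in place of 4-fluorophenyl on a saturated chain carbon bound to a sulfur, a difference counted as 2,5-dichlorophenyl in place of 4-fluorophenyl on a saturated chain carbon bound to a sulfur here. For the measured compounds named here, one measured step bears on it: a 2.3-fold lower number from compound 1 to compound 3 (0.36 log units; beyond the scatter), modest and beyond the scatter, with 4-fluorophenyl replacing 2-bromophenyl at that same place. Going by the values given here, compound 2 differs from compound 3 in more than one place and gives no clean step. By name, 2,5-dichlorophenyl stands closer to the 2-bromophenyl of compound 1, so a modest move towards a higher number is expected. The expected change is a 1.8-fold higher number from compound 3 to compound 4 (0.27 log units; within the scatter), of about the size of the measured step. The estimated value for compound 4 is 22000 nM, with an expected range from 8000 nM to 55000 nM in this assay.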

Compound 4, half-maximal inhibitory concentration: 9850 nM
Beside the measured number, compound 4's estimate is 2.2-fold (0.35 log units) above it; the measured number falls inside the stated range.
By their numbers in this assay, from the lowest: compounds 4 and 3 (each within the scatter of the next); then compound 1; then compound 2.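

At the place on a saturated chain carbon bound to a sulfur, this assay shows a 1.2-fold lower number from compound 3 to compound 4 (0.08 log units; within the scatter), so 2,5-dichlorophenyl and 4-fluorophenyl are not told apart here despite their different halogens. The series also gains a second modest step away from 2-bromophenyl, a 2.7-fold lower number from compound 1 to compound 4 (0.44 log units; beyond the scatter), which lies beyond the scatter and places compound 1 apart from compound 4 as well as from compound 3. No measurement shown accounts for these differences.

As far as these compounds go, whether the numbers of compound 3 and compound 4 hold with an amine or a carboxylic acid on the phenyl ring, or with a longer chain in place of the benzyl carbon, stays open. For the compounds shown here, compound 2 differs from compound 4 in more than one place, so no step to it can be read.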